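This account rests on a few compounds, and the source may have more. Where it says the series, first, only, none or still open, it means among the compounds named here.

In an ADME assay on Huh-7 cells (Homo sapiens) for cytotoxicity, with a stated time of 72 h (a lower number here means that less compound is tolerated, a higher number that more compound is tolerated), compound 1 `CCOc1cccc2c1S(=O)(=O)N=C2C1=C(O)[C@H](C(C)C)N(Cc2ccccc2)C1=O` gives > 33000 nM, which is a limit of the assay and not a number. Compound 2 `CC(C)[C@H]1C(O)=C(C2=NS(=O)(=O)c3c(OCC(N)=O)cccc32)C(=O)N1Cc1ccccc1` gives > 33000 nM, which is also only a limit, so its standing has no exact number behind it. Compound 3 `CC(C)[C@H]1C(O)=C(C2=NS(=O)(=O)c3c(OCCC(N)=O)cccc32)C(=O)N1Cc1ccccc1` has no value yet. It differs from compound 2 in one change: carbamoylmethyl in place of carbamoyl on a saturated chain carbon bound to an oxygen on an aromatic ring. Carbamoylmethyl takes the place of carbamoyl on a saturated chain carbon bound to an oxygen on an aromatic ring, which turns carbamoylmethoxy into 2-carbamoylethoxy. Among the compounds with values here, the one measured step at this place is a step that the two limits leave unreadable from compound 1 to compound 2, and it offers no size to carry over. All that the data show is the limit of > 33000 nM in this assay, at which 2 of the 2 values shown sit. The expected outcome is a step that the limit leaves unreadable from compound 2 to compound 3, with no step beyond the usual scatter and no direction foreseen in this assay. Compound 3 is estimated at 35000 nM, with an expected range from 18000 nM to 70000 nM.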

Compound 3, half-maximal cytotoxic concentration: > 33000 nM
Compound 3 ended at the assay's limit; the forecaster's own chance of this, stated with the estimate: 85%; the middle value lies beyond the limit too.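

In this assay compound 3 gives > 33000 nM as a limit of the assay and not a number. Within the data shown here, no step among compound 1, compound 2 and compound 3 can be read from such limits. Left open is whether these compounds differ at all in this assay and at what concentration each would become toxic to the cells.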